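Working notes: cytotoxicity on HFF cells, compounds 2 and 3

The source may hold more compounds than are shown below. What is called first, only, known or untested is meant among the compounds shown, and "the series" means these compounds.

Compound 1 `CSc1nc(Cl)c2ccn(COCCOC(C)=O)c2n1`: 100000 nM
Compound 2 `CSc1nc(N)c2ccn(COCCO)c2n1`: > 100000 nM (a limit, not a number)

In a functional assay on HFF cells (Homo sapiens) for cytotoxicity (on this read-out higher numbers stand for weaker inhibition and lower numbers for stronger inhibition), compound 1 gives 100000 nM. For compound 2 the read-out in this assay is only a limit, > 100000 nM, a value that sits at the limit of > 100000 nM in this assay, at which 1 of the 2 values shown sits. Compound 2 therefore stands at the weak end of what this assay resolves. Compound 3 `Nc1nc(Cl)nc2c1ccn2COCCO` carries chloro in place of methylsulfanyl on an aromatic carbon. For the measured compounds named here, no step between measured compounds is available to anchor a direction; the expected step from compound 2 to compound 3 is a number no higher from compound 2 to compound 3 (the limit leaves the size open), none beyond the scatter. Compound 3 is expected at 100000 nM, within 30000 nM to 300000 nM, quite possibly again reported as a limit.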

Compound 3, half-maximal inhibitory concentration: > 100000 nM
Compound 3 was reported as a limit; the forecaster's own chance of this, stated with the estimate: 60%; the middle value lies on the limit itself.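

No step can be read from compound 2 to compound 3, as both results are limits and not numbers: the limit of > 100000 nM in this assay, at which 2 of the 3 values shown sit.

As far as these compounds go, whether chloro in place of methylsulfanyl on an aromatic carbon changes the read-out at all remains open.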